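This account rests on a few compounds, and the source may have more. Where it says the series, first, only, none or still open, it means among the compounds named here.

Compound 1 `OC[C@H]1O[C@@H](n2cnc3c(NCc4ccccc4Cl)ncnc32)[C@H](O)[C@@H]1O` gives, in an ADME assay on NIH3T3 cells (Mus musculus) for cytotoxicity, with a stated time of 72 h (a higher number here means a weaker inhibitor, a lower number a stronger inhibitor), a value that is only a limit of the assay: > 166000 nM.
Compound 2 `OC[C@H]1O[C@@H](n2cnc3c(NCc4ccc(Cl)cc4)ncnc32)[C@H](O)[C@@H]1O` gives in this assay likewise only a limit: > 166000 nM.
Compound 3 `OC[C@H]1O[C@@H](n2cnc3c(NCc4ccccc4Br)ncnc32)[C@H](O)[C@@H]1O` gives in this assay again only a limit: > 166000 nM.

Compound 3 therefore stands at the limit, and nothing in the numbers places it above or below its two neighbours, since (the limit of > 166000 nM in this assay, at which 3 of the 3 values shown sit). Within the data shown here, the steps that bear on the change are a step that the two limits leave unreadable from compound 1 to compound 2, a step that the two limits leave unreadable from compound 1 to compound 3 and a step that the two limits leave unreadable from compound 2 to compound 3; none of them has a readable size, so no direction can be drawn from them.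

Compound 4 `COc1cccc(CNc2ncnc3c2ncn3[C@@H]2O[C@H](CO)[C@@H](O)[C@H]2O)c1O` is not yet measured. It differs from compound 3 in this way: 2-hydroxy-3-methoxyphenyl in place of 2-bromophenyl on a saturated chain carbon bound to a nitrogen on an aromatic ring.

Because all three measured values sit at the limit (the limit of > 166000 nM in this assay, at which 3 of the 3 values shown sit), no readable step is expected in this assay either way, and the assay is expected most likely to report a limit again for compound 4. The step from compound 3 is estimated as a step that the limit leaves unreadable from compound 3 to compound 4. Compound 4 is estimated at 200000 nM, with a range from 100000 nM to 500000 nM.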

Compound 4, half-maximal inhibitory concentration: > 166000 nM
Compound 4 was reported as a limit (the forecaster's own chance of this, stated with the estimate: 85%); the middle value lies beyond the limit too.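

In this assay compound 4 again gives only a limit, > 166000 nM. Among these compounds, no step linking compound 4 to compound 1, compound 2 or compound 3 can be read: the limit of > 166000 nM in this assay, at which 4 of the 4 values shown sit. The compounds shown leave open whether these four differ at all in cytotoxicity.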